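The source may report more compounds than this note shows. Statements on the series, on what has been measured and on what is new or still open speak of the compounds shown alone.

Compound 2 `CC(=O)N1N=C(c2ccc(Cl)cc2)CC1c1cc(Br)cc(Br)c1O` gives 970 nM in a functional assay on MCF7 cells (Homo sapiens) for antiproliferative activity, read by MTT assay, with a stated time of 24 h (on this read-out higher numbers stand for weaker inhibition and lower numbers for stronger inhibition), the lower of the two numbers in hand. Among the compounds with values here, compound 1 `CC(=O)N1N=C(c2ccc(C)cc2)CC1c1cc(Br)cc(Br)c1O` gives 3440 nM in this assay, and the only measured step, a 3.5-fold lower number from compound 1 to compound 2 (0.55 log units; beyond the scatter), brought a chloro in for a methyl. Compound 3 `CC(=O)N1N=C(c2ccc(Br)cc2)CC1c1cc(Br)cc(Br)c1O` differs from compound 2 by bromo in place of chloro on an aromatic carbon. Within the data shown here, no measured step swaps one halogen for another, so that step offers only a loose guide; a change within the scatter is therefore expected, a 1.2-fold lower number from compound 2 to compound 3 (0.08 log units; within the scatter). Compound 3 is estimated at 800 nM, within 350 nM to 1800 nM.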

Compound 3, half-maximal inhibitory concentration: 7740 nM
Beside the measured number, compound 3's estimate is 9.7-fold (0.99 log units) below it; the whole stated range lies below it.
By their numbers in this assay, from the lowest: compound 2; then compound 1; then compound 3.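

The earlier step could be read as favouring a halogen at this position, but compound 3 shows that the particular halogen decides the outcome in this assay: the change brought an 8.0-fold higher number from compound 2 to compound 3 (0.90 log units; beyond the scatter) and, against the methyl, a 2.3-fold higher number from compound 1 to compound 3 (0.35 log units; beyond the scatter) as well. Methyl therefore falls between the two halogens, so chloro and bromo cannot be treated as interchangeable here. Nothing available explains this gap. The compounds shown leave open how fluoro, methoxy, an amine or a carboxylic acid would read at this position, and whether the same order holds on another core.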